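Swapping a dichlorophenyl for a hydroxyphenyl

The compounds below may be only part of what the source reports. "The series", "measured", "known", "first", "only" and "open" are said of these compounds alone.

- Compound 1 `O=C(N/N=C/c1ccc(Br)cc1)Nc1ccc(Oc2ccnc3[nH]ccc23)c(F)c1`: 1000 nM
- Compound 2 `O=C(N/N=C/c1cccc(Cl)c1Cl)Nc1ccc(Oc2ccnc3[nH]ccc23)c(F)c1`: "not active" (no number reported)

Both compounds share the same core and were tested in a functional assay on HepG2 cells (Homo sapiens) for antiproliferative activity, read by MTT assay, with a stated time of 72 h; on this read-out higher numbers stand for weaker inhibition and lower numbers for stronger inhibition. Compound 1 gives a real number, which can serve as a reference point. Compound 2 gives no single number and is reported only as "not active" (no number reported), so it cannot be given an exact place on the scale.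

Compound 3 `O=C(N/N=C/c1ccc(O)cc1)Nc1ccc(Oc2ccnc3[nH]ccc23)c(F)c1` keeps the shared core but has not yet been measured. The structural change is 4-hydroxyphenyl in place of 2,3-dichlorophenyl on a carbon with a double bond to nitrogen: 4-hydroxyphenyl takes the place of 2,3-dichlorophenyl on a carbon with a double bond to nitrogen.

With no number for compound 2, the size of this step cannot be stated exactly. The expected direction in this assay is toward stronger inhibition, with a measurable value replacing the missing one. Going by the values given here, the only numerical guide is compound 1 at 1000 nM, so a landing in that general region seems reasonable, although compound 3 may also fail to give a number. For compound 3, the estimated value is 2500 nM, with an expected range from 600 nM to 10000 nM.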

Compound 3, half-maximal inhibitory concentration: 1950 nM
Compound 3: middle estimate off by 1.3-fold (0.11 log units), on the high side; low and high end bracket the measured number.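

In this assay compound 3 gives 1950 nM while compound 2, which carries 2,3-dichlorophenyl in the same place, is reported only as "not active", so the step between them cannot be read as a size. What the new result does show is that 4-hydroxyphenyl on the carbon with a double bond to nitrogen yields a measurable value, and that hydroxy in place of bromo on an aromatic carbon gives a 2.0-fold higher number from compound 1 to compound 3 (0.29 log units; within the scatter) and so leaves the two groups indistinguishable on this read-out. No measured property of these groups is available to explain the result.

The compounds shown leave open whether a methoxy group or an amine in place of the hydroxy would also give a number at this spot on the ring. They also leave open whether the lack of a number for compound 2 goes with the presence of two chlorine atoms or with where they sit, a question that a phenyl ring bearing a single chlorine could begin to address.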